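This account rests on a few compounds, and the source may have more. Where it says the series, first, only, none or still open, it means among the compounds named here.

In an ADME assay (liver) for metabolic stability, with Liver microsome (Homo sapiens) as the target, using microsomes (a higher number here means faster removal of the compound, a lower number slower removal), compound 1 (`Cc1ccc(Oc2cc(C(=O)Nc3cnc(C)cn3)cc3oc(C)cc23)cc1`) reads 47 mL/min/kg and compound 2 (`Cc1cnc(NC(=O)c2cc(Oc3ccc(C(=O)N(C)C)cc3)c3cc(C)oc3c2)cn1`) reads 17 mL/min/kg on the same scale. Between them lies a 2.8-fold lower number from compound 1 to compound 2 (0.44 log units; beyond the scatter) as dimethylcarbamoyl takes the place of methyl on an aromatic carbon. Compound 3 (`Cc1cc2c(Oc3cnc(C(=O)N4CC(C)(C)C4)cn3)cc(C(=O)Nc3cnccn3)cc2o1`) reads 21.2 mL/min/kg here, which is within the scatter of compound 2 and clearly lower than compound 1. Compound 4 (`Cc1cc2c(Oc3cnc(C(=O)N4CC5(COC5)C4)cn3)cc(C(=O)Nc3cnccn3)cc2o1`) has not yet been measured. Its difference from compound 3 is a group of 7 heavy atoms (5 carbon, 1 nitrogen, 1 oxygen; 2 four-membered non-aromatic rings with 1 hetero atom each) in place of a group of 6 heavy atoms (5 carbon, 1 nitrogen; one four-membered non-aromatic ring with 1 hetero atom), on a carbonyl carbon so that 3,3-dimethylazetidin-1-yl leaves the carbonyl carbon. Within the data shown here, no measured step makes this exchange. Among the measured compounds shown here, the only measured step, a 2.8-fold lower number from compound 1 to compound 2 (0.44 log units; beyond the scatter) with a different group changing, bears on it loosely and gives a modest size and a weak lean towards a lower number. The expected change in this assay is a 1.3-fold lower number from compound 3 to compound 4 (0.12 log units; within the scatter) and it is expected to stay within the scatter. For compound 4 the estimate is 16 mL/min/kg with an expected range from 9 mL/min/kg to 27 mL/min/kg overall.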

Compound 4, clearance: 12.9 mL/min/kg
The estimate for compound 4 lay 1.2-fold (0.09 log units) above the measured number, within the range that was stated.
By their numbers in this assay, from the lowest: compounds 4, 2 and 3 (each within the scatter of the next); then compound 1.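

Among these compounds, at the carbonyl carbon, the first measured exchange at this place replaces 3,3-dimethylazetidin-1-yl with a larger group bearing two four-membered rings and gives a 1.6-fold lower number from compound 3 to compound 4 (0.22 log units; within the scatter) in this assay. The shared core therefore tolerates the added ring and the added hydrogen-bond acceptor here without a reading beyond the scatter, which the earlier step, made at a different place, could not show. No supporting measurement accompanies this result, so it offers no account of why the reading holds across the exchange.

Going by these compounds, whether a morpholine or a piperidine on this carbonyl carbon would also stay within the scatter of compound 3 remains open. So does whether the same exchange would give a comparable step on a different core, such as that of compound 2.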